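A few compounds are considered here, and "the series" means these few. Any claim that something is new, unique, unknown or untested is made for them only; others in the source may bear on it.

Of the compounds shown here, three built on a shared core have been measured in a functional assay on NCI-H460 cells (Homo sapiens) for inhibition, read by MTT assay, with a stated time of 72 h; a higher number here means a weaker inhibitor, a lower number a stronger inhibitor. Compound 1 `CN(C)CCn1c(=O)c(=Cc2ccc(O)cc2)s/c1=C1\C(=O)Nc2ccc(Br)cc21` gives 1110 nM, compound 2 `CCN(CC)CCCn1c(=O)c(=Cc2cc(OC)c(OC)c(OC)c2)s/c1=C1\C(=O)Nc2ccc(C)cc21` gives 2670 nM, and compound 3 `CCN(CC)CCCn1c(=O)c(=Cc2ccc(F)cc2F)s/c1=C1\C(=O)Nc2ccccc21` gives 5470 nM. Compound 2 therefore stands second highest of the three numbers; its nearest neighbour is compound 3 and its furthest is compound 1, and both of those gaps lie beyond the usual scatter. Compound 4 `CCN(CC)CCCn1c(=O)c(=Cc2ccccc2O)s/c1=C1\C(=O)Nc2ccc(C)cc21` has not yet been measured in this assay. It differs from compound 2 in a single place: 2-hydroxyphenyl in place of 3,4,5-trimethoxyphenyl on a double-bonded chain carbon bound to an aromatic carbon. Among the compounds with values here, no pair of measured compounds isolates this change, so any expectation rests loosely on compound 1, which gives 1110 nM but differs from compound 4 in more than one place. The step is expected to be a modest lowering of the number, a 1.5-fold lower number from compound 2 to compound 4 (0.17 log units; within the scatter), near the edge of the scatter. Compound 4 is accordingly estimated at 1800 nM, with a likely range from 700 nM to 4500 nM.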

Compound 4, half-maximal inhibitory concentration: 11300 nM
Beside the measured number, compound 4's estimate is 6.3-fold (0.80 log units) below it; measured number outside the range, above it.
By their numbers in this assay, from the lowest: compound 1; then compound 2; then compound 3; then compound 4.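

In this assay, within the data shown here, the change to 2-hydroxyphenyl from 3,4,5-trimethoxyphenyl gives a 4.2-fold higher number from compound 2 to compound 4 (0.63 log units; beyond the scatter) and is the first single-place step read at this position. It shows that the group on this double-bonded chain carbon can shift the number, here toward weaker inhibition, while the rest of the molecule stays fixed. No measurement offered here explains the step.

The compounds shown leave open whether the hydroxyl or the loss of the methoxy groups drives this shift. An unsubstituted phenyl or a 2-methoxyphenyl at this place, on the rest of compound 4, would separate the two.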